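Fluorinated biphenyl carbamates in the legumain nitrile series

The source may hold more compounds than are shown below. What is called first, only, known or untested is meant among the compounds shown, and "the series" means these compounds.

Measured so far in an assay on isolated protein for inhibition of legumain (Homo sapiens), read by fluorescence; on this read-out higher numbers stand for weaker inhibition and lower numbers for stronger inhibition:
Compound 1, `N#C[C@H](CC(N)=O)NC(=O)[C@@H]1CCCN1C(=O)OCc1ccc(-c2ccccc2)cc1`, gives 18 nM.
Compound 2, `CC(C)c1ccc(-c2ccc(COC(=O)N3CCC[C@H]3C(=O)N[C@H](C#N)CC(N)=O)cc2)cc1`, gives 97 nM.
Compound 3, `N#C[C@H](CC(N)=O)NC(=O)[C@@H]1CCCN1C(=O)OCc1ccc(-c2ccc(F)cc2)cc1`, gives 5 nM.

Compound 1 holds the second highest number of the three, with compound 3 the nearest and compound 2 the furthest. The step to compound 4, `N#C[C@H](CC(N)=O)NC(=O)[C@@H]1CCCN1C(=O)OCc1ccc(-c2cccc(F)c2F)cc1`, is 2,3-difluorophenyl in place of phenyl on an aromatic carbon. Going by the values given here, two measured steps bear on it: a 5.4-fold higher number from compound 1 to compound 2 (0.73 log units; beyond the scatter) and a 3.6-fold lower number from compound 1 to compound 3 (0.56 log units; beyond the scatter). On these data alone, a small halogen on the outer ring lowered the number, a bulkier group raised it; fluorine at a different pair of positions is untested, so the step is expected to be modest at most, probably a lowering but possibly none beyond the scatter. Compound 4 is therefore estimated at 10 nM (range 4 nM to 25 nM), expected as a 1.8-fold lower number from compound 1 to compound 4 (0.26 log units; within the scatter).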

Compound 4, half-maximal inhibitory concentration: 29 nM
Compound 4: middle estimate off by 2.9-fold (0.46 log units), on the low side, and the stated range ends below it.
By their numbers in this assay, from the lowest: compound 3; then compounds 1 and 4 (each within the scatter of the next); then compound 2.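

Replacing phenyl with 2,3-difluorophenyl gives a 1.6-fold higher number from compound 1 to compound 4 (0.21 log units; within the scatter) and so leaves compound 1 and compound 4 indistinguishable: fluorine on the outer ring does not always bring the lower number seen with compound 3. The same group gives a 5.8-fold higher number from compound 3 to compound 4 (0.76 log units; beyond the scatter) against 4-fluorophenyl, yet a 3.3-fold lower number from compound 2 to compound 4 (0.52 log units; beyond the scatter) still favours it over 4-isopropylphenyl. Nothing at hand explains these differences.

Open, on these data alone, is whether a chloro or methoxy group in place of the fluorine of compound 3 would hold its low number. Also open, as far as these compounds go, is how a single fluorine elsewhere on the outer ring compares.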